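Aryl ether exchange from compound 2 toward compound 3

The source may report more compounds than this note shows. Statements on the series, on what has been measured and on what is new or still open speak of the compounds shown alone.

Two members of the series have been run in a functional assay on A549 cells (Homo sapiens) for inhibition, read by MTT assay, with a stated time of 72 h, tested at 20 uM; on this read-out higher numbers stand for more inhibition at the one concentration tested (going by the name of the read-out) and lower numbers for less inhibition. Compound 1, `CNC(=O)c1cc(Oc2ccc(Nc3nccc(N4CCCCC4)n3)cc2)ccn1`, gives 63.4% in this assay. Compound 2, `c1ccc2c(c1)CCN(c1ccnc(Nc3ccc(Oc4ncnc5ccsc45)cc3)n1)C2`, gives 54.9% in this assay, the lower of the two numbers, though its gap to compound 1 lies within the scatter, so the two cannot be ordered. Compound 3, `CNC(=O)c1cc(Oc2ccc(Nc3nccc(N4CCc5ccccc5C4)n3)cc2)ccn1`, awaits measurement. Relative to compound 2 the change is a group of 10 heavy atoms (7 carbon, 2 nitrogen, 1 oxygen; one six-membered aromatic ring with 1 hetero atom) in place of a group of 9 heavy atoms (6 carbon, 2 nitrogen, 1 sulfur; one five-membered aromatic ring with 1 hetero atom, one six-membered aromatic ring with 2 hetero atoms), on an oxygen on an aromatic ring. The entering group is the same aryl ether that compound 1 carries, so compound 3 joins that ether to the remainder of compound 2. Going by the values given here, no measured pair isolates this exchange. Compound 1 and compound 2 differ at two places yet sit within the scatter of each other. On that basis the step is expected to be a number 4.1 percentage points higher from compound 2 to compound 3 (within the scatter), not beyond the scatter. Compound 3 is estimated at 59% in this assay, with a range from 42% to 76%.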

Compound 3, a percentage reported as inhibition, at one concentration (the size of the read-out at that concentration, not a potency): 59.6%
Beside the measured number, compound 3's estimate is 0.6 percentage points below it; the range from low to high includes it.
By their numbers in this assay, from the lowest: compounds 2, 3 and 1 (each within the scatter of the next).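

In this assay the exchange on an oxygen on an aromatic ring, with 2-(methylcarbamoyl)pyridin-4-yl entering, gives a number 4.7 percentage points higher from compound 2 to compound 3 (within the scatter) and so does not separate the two aryl ethers on this read-out. The second place now has its own pair: 1,2,3,4-tetrahydroisoquinolin-2-yl in place of piperidin-1-yl on an aromatic carbon gives a number 3.8 percentage points lower from compound 1 to compound 3 (within the scatter) and leaves that exchange unresolved as well. Going by these compounds alone, each change is thus read alone for the first time, and nothing at hand bears on the cause of either step.

From the compounds shown here alone, it remains open whether a morpholine or a dimethylamino group on that aromatic carbon would give a step beyond the scatter. The same holds for a carboxylic acid in place of the methylcarbamoyl group on the pyridine ring.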